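Replacing the Imidazole Chain End with Hydroxy

The source may report more compounds than this note shows. Statements on the series, on what has been measured and on what is new or still open speak of the compounds shown alone.

Measured in a functional assay on ECa-109 cells (Homo sapiens) for antiproliferative activity, read by MTT assay, with a stated time of 48 h; a higher number here means a weaker inhibitor, a lower number a stronger inhibitor:
- compound 1 `Cn1cc(C2=C(c3nn(CCCn4cccc4)c4ncccc34)C(=O)NC2=O)c2ccccc21`: > 100000 nM (a limit)
- compound 2 `Cn1cc(C2=C(c3nn(CCCN4CCCCC4)c4ncccc34)C(=O)NC2=O)c2ccccc21`: 42300 nM
- compound 3 `Cn1cc(C2=C(c3nn(CCCCn4ccnc4)c4ncccc34)C(=O)NC2=O)c2ccccc21`: 23500 nM

Compound 3 gives 23500 nM, level within the scatter with compound 2 at 42300 nM, as a 1.8-fold lower number from compound 2 to compound 3 (0.26 log units; within the scatter) shows. The entry for compound 1, > 100000 nM, is a limit. On these data alone, the remaining steps, an at least 2.3-fold lower number from compound 1 to compound 2 (0.37 log units; beyond the scatter) and an at least 4.2-fold lower number from compound 1 to compound 3 (0.62 log units; beyond the scatter), both start from that limit, so their true sizes are unknown.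

Compound 4 `Cn1cc(C2=C(c3nn(CCCO)c4ncccc34)C(=O)NC2=O)c2ccccc21` carries hydroxy in place of (1H-imidazol-1-yl)methyl on a saturated chain carbon, three bonds along the chain from an aromatic nitrogen. Among the compounds with values here, no measured step introduces hydroxy. The three steps show only that changing the chain end can shift the number in this assay, and the closest comparison, a 1.8-fold lower number from compound 2 to compound 3 (0.26 log units; within the scatter), stays within the scatter. The expected change is a 1.3-fold higher number from compound 3 to compound 4 (0.11 log units; within the scatter), which is no clear step beyond the scatter, though with real uncertainty in either direction. For compound 4 the estimated value is 30000 nM, with an expected range of 8000 nM to 100000 nM.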

Compound 4, half-maximal inhibitory concentration: > 100000 nM
Compound 4: a limit, no number; the forecaster's own chance of this, stated with the estimate: 20%; middle value at least 3.3-fold (0.52 log units) from the limit.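

In this assay compound 4 gives > 100000 nM, which is a limit. Hydroxy on a saturated chain carbon, three bonds along the chain from an aromatic nitrogen, compares poorly with both chain ends that gave a number, with an at least 4.2-fold higher number from compound 3 to compound 4 (0.62 log units; beyond the scatter) and an at least 2.3-fold higher number from compound 2 to compound 4 (0.37 log units; beyond the scatter), so the limit seen earlier is no longer confined to 1H-pyrrol-1-yl, and a chain end with no ring reaches it too. The step between compound 1 and compound 4 joins two limits and cannot be read, and the pair shares one limit: the limit of > 100000 nM in this assay, at which 2 of the 4 values shown sit.

The compounds shown leave open whether an amine such as dimethylamino or a carboxylic acid at this chain end would give a number in this assay. They also leave open whether a longer chain ending in hydroxy would do so.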